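Swapping the phenyl for a furan on a shared core

The source may hold more compounds than are shown below. What is called first, only, known or untested is meant among the compounds shown, and "the series" means these compounds.

Measured so far in a functional assay on DU-145 cells (Homo sapiens) for cytotoxicity, read by CCK-8 assay and cell counting, with a stated time of 2 days; on this read-out lower numbers stand for stronger inhibition and higher numbers for weaker inhibition:
- compound 1 `Oc1cccc(-c2cc(-c3ccc(Cl)cc3)nc(-c3cccs3)c2)c1` gives 11600 nM
- compound 2 `Oc1cccc(-c2cc(-c3ccc(Cl)cc3)nc(-c3ccccn3)c2)c1` gives 8090 nM
- compound 3 `Oc1cccc(-c2cc(-c3ccccc3)nc(-c3ccc(Cl)cc3)c2)c1` gives 11200 nM

Compound 3 stands second highest of these three numbers, with a 1.0-fold lower number from compound 1 to compound 3 (0.02 log units; within the scatter) to its nearest neighbour and a 1.4-fold higher number from compound 2 to compound 3 (0.14 log units; within the scatter) to its furthest; all three compounds sit within the scatter of one another. Compound 4 `Oc1cccc(-c2cc(-c3ccc(Cl)cc3)nc(-c3ccco3)c2)c1` differs from compound 3 in one place: furan-2-yl in place of phenyl on an aromatic carbon. Within the data shown here, the steps that bear on this change are the other swaps at the same position, a 1.4-fold lower number from compound 1 to compound 2 (0.16 log units; within the scatter) and a 1.0-fold lower number from compound 1 to compound 3 (0.02 log units; within the scatter), each within the scatter. The expected step is therefore a 1.1-fold lower number from compound 3 to compound 4 (0.03 log units; within the scatter), no change beyond the scatter in this assay. Compound 4 is estimated at 10500 nM, with a range from 5000 nM to 22000 nM.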

Compound 4, half-maximal inhibitory concentration: 11400 nM
Estimate against measurement, compound 4: 1.1-fold (0.04 log units) below; measured number inside the range.
By their numbers in this assay, from the lowest: compounds 2, 3, 4 and 1 (each within the scatter of the next).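

In this assay, furan-2-yl at this position, next to the ring nitrogen, gives no change beyond the scatter against any of the other three groups: a 1.0-fold higher number from compound 3 to compound 4 (0.01 log units; within the scatter), a 1.4-fold higher number from compound 2 to compound 4 (0.15 log units; within the scatter) and a 1.0-fold lower number from compound 1 to compound 4 (0.01 log units; within the scatter). The earlier compounds shown here covered only six-membered rings and thiophen-2-yl, so this adds an oxygen-containing five-membered aromatic ring, and with it a hydrogen-bond acceptor, to the swaps that leave the number within the scatter. No evidence is available on why these swaps change so little.

An amine, a carboxylic acid or a longer alkyl chain at this position might still move the number beyond the scatter. From the compounds shown here alone, whether furan-2-yl behaves the same way with a different group in place of the 3-hydroxyphenyl or 4-chlorophenyl also stays open.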